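From phenyl to tert-butyl on a sulfur

This account rests on a few compounds, and the source may have more. Where it says the series, first, only, none or still open, it means among the compounds named here.

- Compound 1 `Cc1ccc(C(=O)CSC(=S)SC(C)(C)C)cc1`: 31600 nM
- Compound 2 `O=C(CSC(=S)Sc1ccccc1)c1ccc(Cl)c(Cl)c1`: 20000 nM
- Compound 3 `CCSC(=S)SCC(=O)c1ccc(CNC(=O)OCc2cccnc2)cc1`: 20000 nM

All three compounds were tested in a functional assay on HeLa cells (Homo sapiens) for antiproliferative activity, read by resazurin assay (on this read-out higher numbers stand for weaker inhibition and lower numbers for stronger inhibition), and their values lie within the scatter of one another. Compound 2 gives 20000 nM, level with compound 3, and its gap to compound 1 also stays within the scatter.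

The unmeasured compound 4 `CC(C)(C)SC(=S)SCC(=O)c1ccc(Cl)c(Cl)c1` keeps the rest of compound 2 but carries tert-butyl in place of phenyl on a sulfur whose other neighbour is the thiocarbonyl carbon: tert-butyl in place of phenyl on a sulfur. Within the data shown here, no measured pair isolates this change, so the evidence is indirect. Compound 1 also carries tert-butyl on such a sulfur and gives 31600 nM, although it differs from compound 4 elsewhere as well.

No step beyond the scatter is expected in this assay, and the estimated change is a 1.3-fold higher number from compound 2 to compound 4 (0.10 log units; within the scatter). For compound 4 the estimated value is 25000 nM, with an expected range from 10000 nM to 60000 nM.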

Compound 4, half-maximal inhibitory concentration: 10000 nM
Compound 4: the middle estimate sits 2.5-fold (0.40 log units) above what was measured; the range from low to high includes it.
By their numbers in this assay, from the lowest: compounds 4, 2, 3 and 1 (each within the scatter of the next, the first and the last beyond it).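

Among these compounds, the pair gives the first direct reading of this change: in this assay, tert-butyl in place of phenyl on a sulfur whose other neighbour is the thiocarbonyl carbon amounts to a 2.0-fold lower number from compound 2 to compound 4 (0.30 log units; within the scatter). At this position, then, a group of four carbons with no ring and a six-membered aromatic ring of carbon give values within the scatter of each other, with the rest of the molecule held constant. Nothing available bears on why the two groups read alike.

Going by these compounds, whether a carboxylic acid, an amine or a longer chain carrying either would also stay within the scatter on this sulfur remains open. So does whether the same change reads alike on the cores of compound 1 and compound 3.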